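From 4-Hydroxyphenyl to 3,5-Dihydroxyphenyl at the Assay Limit

The compounds below may be only part of what the source reports. "The series", "measured", "known", "first", "only" and "open" are said of these compounds alone.

Compound 1 `Oc1ccc(CNc2ncnc3c2ncn3C2CCCCO2)cc1` is the starting point in an ADME assay on MCF7 cells (Homo sapiens) for cytotoxicity, with a stated time of 72 h; a higher number here means a weaker inhibitor, a lower number a stronger inhibitor. There, compound 1 gives > 100000 nM, which is a limit of the assay and not a number. Compound 2 `COc1cccc(CNc2ncnc3c2ncn3C2CCCCO2)c1O` gives > 100000 nM, and this too is a limit. Compound 3 `COc1cc(CNc2ncnc3c2ncn3C2CCCCO2)ccc1O` gives > 100000 nM, again a limit. The whole series therefore stands at one place: the limit of > 100000 nM in this assay, at which 3 of the 3 values shown sit. No measured value yet separates compound 1 from the others.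

Compound 4 `Oc1cc(O)cc(CNc2ncnc3c2ncn3C2CCCCO2)c1` carries a new change: 3,5-dihydroxyphenyl in place of 4-hydroxyphenyl on a saturated chain carbon bound to a nitrogen on an aromatic ring. It puts 3,5-dihydroxyphenyl in place of 4-hydroxyphenyl on a saturated chain carbon bound to a nitrogen on an aromatic ring. Within the data shown here, only one measured step touches the same aromatic ring, and it adds a methoxy in place of hydrogen on an aromatic carbon: a step that the two limits leave unreadable from compound 1 to compound 3. Since that step that the two limits leave unreadable from compound 1 to compound 3 has no readable size, it offers no size or direction to carry over, so no step beyond the usual scatter is expected in this assay. The expected step is a step that the limit leaves unreadable from compound 1 to compound 4. For compound 4 the estimate is 120000 nM, with an expected range from 50000 nM to 300000 nM, and the assay is expected to report only a limit once more.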

Compound 4, half-maximal inhibitory concentration: > 100000 nM
Compound 4 gave a limit, no number (the forecaster's own chance of this, stated with the estimate: 90%); the middle value lies beyond the limit too.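

In this assay compound 4 gives > 100000 nM as a limit of the assay and not a number. No step can be read from compound 1 to compound 4, because both values are limits: the limit of > 100000 nM in this assay, at which 4 of the 4 values shown sit. The compounds shown leave open whether any change to the aromatic ring of compound 1 gives a measurable value in this assay at all.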